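Notes on a glycinamide series: compound 1 to compound 4

The compounds below may be only part of what the source reports. "The series", "measured", "known", "first", "only" and "open" are said of these compounds alone.

Measured so far:
compound 1 `O=C(CN(c1ncnc2c1ncn2C1CCCCO1)C1CC1)NCC(=O)OCc1ccccc1`: 40.4%
compound 2 `O=C(OCc1ccccc1)[C@@H]1CCCN1C(=O)CN(c1nc(Cl)nc2[nH]cnc12)C1CC1`: 34.4%
compound 3 `CC(C)[C@H](NC(=O)CN(c1nc(Cl)nc2[nH]cnc12)C1CC1)C(=O)O`: 38.8%

Three compounds have been run in a functional assay on the whole organism (Tail, strain ICR) with Mus musculus as the target, in the tail flick test, with a stated time of 60 min, at a dose of 25 umol/kg by the oral route; on this read-out higher numbers stand for a stronger effect at the one dose given and lower numbers for a weaker effect. Compound 1 gives the highest of the three numbers, but the gap to compound 3 and the gap to compound 2 both lie within the scatter of repeated measurements, so no order among the three can be read from these values.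

Compound 4 `CC(C)[C@H](NC(=O)CN(c1ncnc2c1ncn2C1CCCCO1)C1CC1)C(=O)OCc1ccccc1` has not yet been measured. It differs from compound 1 in one place: isopropyl in place of hydrogen on a saturated chain carbon bound to an amide-type nitrogen and a carbonyl carbon. Among the measured compounds shown here, no pair of measured compounds differs in one place, so no measured step can be consulted directly. Compound 3 carries the same isopropyl on the same position of the chain while differing elsewhere, and in this assay compound 3 sits within the scatter of compound 1. Given that, the step expected from compound 1 to compound 4 is a number 0.4 percentage points lower from compound 1 to compound 4 (within the scatter), which is expected to stay within the scatter in either direction. For compound 4 the estimated value in this assay is 40%, with an expected range from 28% to 52%.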

Compound 4, a percentage reported as activity, at one dose (the size of the read-out at that dose, not a potency): 34.9%
The estimate for compound 4 lay 5.1 percentage points above the measured number; the measured number falls inside the stated range.
By their numbers in this assay, from the lowest: compounds 2, 4, 3 and 1 (each within the scatter of the next).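

In this assay the series now has its first step that changes one place only: isopropyl in place of hydrogen on a saturated chain carbon bound to an amide-type nitrogen and a carbonyl carbon gives a number 5.5 percentage points lower from compound 1 to compound 4 (within the scatter) and so does not separate the two compounds. This position therefore carries the added isopropyl, with its 3 carbon atoms, without a change in the read-out that exceeds the scatter at this one dose. No measurement available here bears on why the step has this size.

As far as these compounds go, whether a methyl group, a longer chain or an amine on the same carbon would also stay within the scatter of compound 1 remains open. The read-out comes from a single dose and time. From the compounds shown here alone, it gives no potency, and any difference between compound 1 and compound 4 under other conditions also remains open.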